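Carbonyl, sulfonyl and urea links on the ring nitrogen

A few compounds are considered here, and "the series" means these few. Any claim that something is new, unique, unknown or untested is made for them only; others in the source may bear on it.

Measured compounds:
compound 1 `CN(C(=O)c1ccc(Cl)cc1)c1ccc2[nH]c(-c3n[nH]c4ccccc34)cc2n1`, 2420 nM
compound 2 `Cc1ccc(S(=O)(=O)N(C)c2ccc3[nH]c(-c4n[nH]c5ccccc45)cc3n2)cc1`, 16300 nM
compound 3 `CN(c1ccc2[nH]c(-c3n[nH]c4ccccc34)cc2n1)S(=O)(=O)c1ccc(Cl)cc1`, 12700 nM

All three share one core and differ only in the group on the nitrogen on the aromatic ring. In a functional assay on SMMC-7721 cells (Homo sapiens) for antiproliferative activity, read by MTT assay, with a stated time of 72 h (on this read-out lower numbers stand for stronger inhibition and higher numbers for weaker inhibition), compound 3 stands second highest of the three numbers; its nearest neighbour is compound 2, and the step of a 1.3-fold lower number from compound 2 to compound 3 (0.11 log units; within the scatter) lies within the scatter. Compound 1 stands furthest off, the step of a 5.2-fold higher number from compound 1 to compound 3 (0.72 log units; beyond the scatter) being beyond the scatter, as is a 6.7-fold higher number from compound 1 to compound 2 (0.83 log units; beyond the scatter).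

The next compound, compound 4 `CN(C(=O)Nc1ccccc1)c1ccc2[nH]c(-c3n[nH]c4ccccc34)cc2n1`, is reached by the change (phenylcarbamoyl in place of (4-chlorophenyl)sulfonyl on a nitrogen on an aromatic ring). For the measured compounds named here, no measured step swaps a sulfonyl for a carbamoyl, so the bearing steps are indirect: both moves from the carbonyl of compound 1 to a sulfonyl raised the number modestly, and the carbamoyl of compound 4 is again a carbonyl-linked group. A modest drop is therefore expected in this assay, the step of a 3.6-fold lower number from compound 3 to compound 4 (0.56 log units; beyond the scatter) being the estimated size, because compound 1 gives 2420 nM. For compound 4 the expected value is 3500 nM, in the range 1200 nM to 10000 nM.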

Compound 4, half-maximal inhibitory concentration: 280 nM
Estimate against measurement, compound 4: 13-fold (1.10 log units) above; measured number outside the range, below it.
By their numbers in this assay, from the lowest: compound 4; then compound 1; then compounds 3 and 2 (each within the scatter of the next).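

Phenylcarbamoyl on the nitrogen on an aromatic ring gives the lowest number of the set in this assay, and the large steps from the sulfonyl groups are a 45-fold lower number from compound 3 to compound 4 (1.66 log units; beyond the scatter) and a 58-fold lower number from compound 2 to compound 4 (1.77 log units; beyond the scatter). A carbonyl link alone therefore does not set the level at this position: with the link kept, anilino in place of 4-chlorophenyl on a carbonyl carbon still gives an 8.6-fold lower number from compound 1 to compound 4 (0.94 log units; beyond the scatter), so the group on the carbonyl carbon also counts. Nothing at hand explains these steps.

Open, from the compounds shown here alone, is whether a chloro or methyl on the phenyl ring of the phenylcarbamoyl group would keep this low number. Also open, going by these compounds, is whether the anilino group could give way to a saturated amine such as morpholine or to a longer chain such as benzylamino.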